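This account rests on a few compounds, and the source may have more. Where it says the series, first, only, none or still open, it means among the compounds named here.

The measured compounds:
compound 1, `COc1ccc(-c2cnc(NC(=O)c3ccccn3)n2C)cc1`, which in a toxicity assay on THP-1 cells (Homo sapiens) for inhibition (a lower number here means that less compound is tolerated, a higher number that more compound is tolerated), gives the limit > 100000 nM.
compound 2, `COc1ccc(-c2cnc(NC(=O)c3cccc(C#N)c3)n2C)cc1`, which in this assay gives the limit > 100000 nM.
compound 3, `COc1ccc(C(=O)Nc2ncc(-c3ccc(OC)cc3)n2C)cc1`, which in this assay gives the limit > 100000 nM.

Compound 3 therefore stands at the top of what the numbers show: its value is a limit, not a number, and the two other values shown are limits as well. All three sit at the limit of > 100000 nM in this assay, at which 3 of the 3 values shown sit, so none of the three compounds can be ordered against another. The steps among them are accordingly not readable: a step that the two limits leave unreadable from compound 1 to compound 2, a step that the two limits leave unreadable from compound 1 to compound 3 and a step that the two limits leave unreadable from compound 2 to compound 3 all run from one limit to another.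

Compound 4, `COc1ccc(-c2cnc(NC(=O)c3cnc[nH]3)n2C)cc1`, has not yet been measured. It differs from compound 3 in one place: 1H-imidazol-5-yl in place of 4-methoxyphenyl on a carbonyl carbon. The three measured steps are the only ones that touch this position on the carbonyl carbon, and none of them gives a readable size, so they set no direction for the new change beyond the observation that every group tried there so far left the compound at the limit.

Compound 4 is therefore expected to remain near the limit as well, with an estimated value of 100000 nM and a range from 40000 nM to 200000 nM. The expected step from compound 3 is a number no higher from compound 3 to compound 4 (the limit leaves the size open), meaning no change that can be read beyond the scatter.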

Compound 4, half-maximal cytotoxic concentration: > 100000 nM
Compound 4: a limit, no number; the forecaster's own chance of this, stated with the estimate: 85%; the middle value sits exactly at the limit.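

In this assay compound 4 gives > 100000 nM, which is a limit and not a number. The steps to compound 4 from compound 1, compound 2 and compound 3 therefore cannot be read, as all four compounds sit at the same limit: the limit of > 100000 nM in this assay, at which 4 of the 4 values shown sit.

The compounds shown leave open what the actual half-maximal cytotoxic concentration of each compound is, and whether any group on the carbonyl carbon changes it.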